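A few compounds are considered here, and "the series" means these few. Any claim that something is new, unique, unknown or untested is made for them only; others in the source may bear on it.

Compound 1 `O=C(N/N=C/N1CCN(c2cc3c(cc2F)c(=O)c(C(=O)O)cn3C2CC2)CC1)c1ccc(F)cc1` — > 763000 nM
Compound 2 `O=C(N/N=C/N1CCN(c2cc3c(cc2F)c(=O)c(C(=O)O)cn3C2CC2)CC1)c1cccc(F)c1` — > 305000 nM

In an ADME assay on PBMC cells (Homo sapiens) for cytotoxicity, read by MTT assay (on this read-out higher numbers stand for weaker inhibition and lower numbers for stronger inhibition), compound 1 gives > 763000 nM, which is a limit of the assay and not a measured number. Compound 2 gives > 305000 nM in this assay, again only a limit. The step that the two limits leave unreadable from compound 1 to compound 2 therefore cannot be read; the two values sit at the limit of > 763000 nM in this assay, at which 1 of the 2 values shown sits, and at the limit of > 305000 nM in this assay, at which 1 of the 2 values shown sits, and nothing more can be said of the change at the carbonyl carbon.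

Compound 3 `CCn1cc(C(=O)O)c(=O)c2cc(F)c(N3CCN(/C=N/NC(=O)c4ccc(F)cc4)CC3)cc21` differs from compound 1 by ethyl in place of cyclopropyl on an aromatic nitrogen. For the measured compounds named here, no measured step touches this position; the only step available, a step that the two limits leave unreadable from compound 1 to compound 2, concerns another part of the molecule and is itself unreadable. What compound 1 shows is that the shared core with the fluorophenyl hydrazide reaches the top of the assay without a number, so compound 3 is expected to behave alike, with a step of an at least 1.0-fold lower number from compound 1 to compound 3 (0.03 log units; that floor lies within the scatter) that is expected to be none beyond the scatter. For compound 3 the estimate in this assay is 700000 nM, expected to fall between 300000 nM and 1500000 nM, most probably as a limit again.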

Compound 3, half-maximal inhibitory concentration: > 331000 nM
Compound 3 gave a limit, no number; the forecaster's own chance of this, stated with the estimate: 85%; the middle value does not contradict the limit.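

In this assay compound 1 and compound 3 each give only a limit and not a number, and the step between them, ethyl in place of cyclopropyl on an aromatic nitrogen, cannot be read. The compounds shown leave open what number compound 1, compound 2 or compound 3 would give in this assay, and whether either change shifts it.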